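Series notes: the step from compound 2 to compound 4

This account rests on a few compounds, and the source may have more. Where it says the series, first, only, none or still open, it means among the compounds named here.

Measured so far:
- compound 1 `COc1ccc(OCCOc2ccc3c(c2)C(=C(C)C)C(=O)N3)cc1`: "not active" (no number reported)
- compound 2 `CC(C)=C1C(=O)Nc2ccc(OCc3ccc(F)cc3)cc21`: "not active" (no number reported)
- compound 3 `CC(C)C1C(=O)Nc2ccc(OCc3cccc(F)c3)cc21`: 12.7%

All three were run in an assay on cells for inhibition of Amine oxidase [flavin-containing] B (Homo sapiens), read by fluorescence, with stated times of 30 min and 15 min, tested at 1 uM; a lower number here means less inhibition, a higher number more inhibition at the concentration tested (going by the name of the read-out). Compound 1 returns "not active" (no number reported) in this assay, with no number attached. Compound 2 likewise returns "not active" (no number reported), so compound 2 stands without a single number; it is one of two entries in the set that carry no figure at all. Only compound 3 gives a figure, 12.7%, and that figure is itself small. Within the data shown here, no pair of measured compounds differs in one place, so no step size is available between them.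

Compound 4 `CC(C)=C1C(=O)Nc2ccc(OCCc3ccccc3)cc21` has not been measured. Relative to compound 2 the change is benzyl in place of 4-fluorophenyl on a saturated chain carbon bound to an oxygen on an aromatic ring. The 4-fluorophenyl leaves and a benzyl enters, at the same saturated chain carbon bound to an oxygen on an aromatic ring; the rest of the shared core is unchanged.

Among the measured compounds shown here, with compound 2 carrying no number, no step in this assay can be computed from it; nothing in the set suggests a move beyond the scatter in either direction. Compound 4 is therefore expected to sit low, near 10%, in a range from 0% to 30%, with a real chance that only an inactive flag is reported.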

Compound 4, a percentage reported as inhibition, at one concentration (the size of the read-out at that concentration, not a potency): "not active" (no number reported)
Nothing numeric was reported for compound 4, and the estimate cannot be compared.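

In this assay compound 2 gives "not active" (no number reported) and compound 4 gives "not active" (no number reported) as well, so no step can be read between them. The compounds shown leave open whether benzyl in place of 4-fluorophenyl changes inhibition at all. No measured evidence bears on this result.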